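This account rests on a few compounds, and the source may have more. Where it says the series, first, only, none or still open, it means among the compounds named here.

Measured compounds, with their numbers in a functional assay on ME18 cells (Homo sapiens) for cytotoxicity, read by MTT assay, with a stated time of 48 h; on this read-out lower numbers stand for stronger inhibition and higher numbers for weaker inhibition:
compound 1 `Cc1ccc(C(c2c[nH]c3ccccc23)c2c[nH]c3ccccc23)cc1` gives 35900000 nM
compound 2 `Fc1cc(F)cc(C(c2c[nH]c3ccccc23)c2c[nH]c3ccccc23)c1` gives 17000000 nM
compound 3 `Ic1ccc2[nH]cc(Cc3c[nH]c4ccc(I)cc34)c2c1` gives 17300000 nM

Compound 3 stands second highest of the three numbers. Its nearest neighbour is compound 2, whose number lies within the scatter of it; compound 1 gives a number that sits beyond the scatter above compound 3. Going by the values given here, no single-point step exists between compound 3 and either other compound, as each differs from it in more than one place.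

Compound 4 `Cc1ccc(C(c2c[nH]c3ccc(I)cc23)c2c[nH]c3ccc(I)cc23)cc1` is not yet measured. Relative to compound 3 the change is 4-methylphenyl in place of hydrogen on a saturated chain carbon bound to two aromatic carbons: the carbon bridging the two halves of the shared core carries a hydrogen in compound 3 and the 4-methylphenyl group in compound 4, both iodine atoms kept.

Among the compounds with values here, no measured step covers hydrogen against 4-methylphenyl on this carbon. Within the data shown here, the only measured step, a 2.1-fold lower number from compound 1 to compound 2 (0.32 log units; beyond the scatter), exchanges one aryl group for another on that carbon and was modest in size. Compound 1, which carries the 4-methylphenyl group on the same carbon, gives the highest number of the set. On that basis the expected step in this assay is small and, if anything, toward a higher number, a 1.4-fold higher number from compound 3 to compound 4 (0.16 log units; within the scatter). Compound 4 is accordingly estimated at 25000000 nM, with a range from 8000000 nM to 80000000 nM.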

Compound 4, half-maximal inhibitory concentration: 21100000 nM
Compound 4: middle estimate off by 1.2-fold (0.07 log units), on the high side, within the range that was stated.
By their numbers in this assay, from the lowest: compounds 2, 3, 4 and 1 (each within the scatter of the next, the first and the last beyond it).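

In this assay, going by these compounds alone, a 1.2-fold higher number from compound 3 to compound 4 (0.09 log units; within the scatter) gives the first direct reading of an aryl group against hydrogen on a saturated chain carbon bound to two aromatic carbons, with both iodine atoms kept, and the two numbers stay within the scatter of each other. So adding the 4-methylphenyl group, with its 7 heavy atoms and one six-membered aromatic ring, produces no readable change at this position in the iodinated series, whereas a 2.1-fold lower number from compound 1 to compound 2 (0.32 log units; beyond the scatter) exchanged only one aryl group for another and could not show what the bare carbon contributes. No measurement on hand offers an explanation for this result.

Within the data shown here, only one hydrogen-to-aryl exchange can be read, so it remains open whether a smaller group such as methyl, or an aryl group carrying an amine or a carboxylic acid, would give a step beyond the scatter at this carbon. Among these compounds, the effect of the iodine atoms also remains open, as no pair of compounds here differs in those atoms alone.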